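Swapping Diethylamino for tert-Butyl on the Aryl Ring

The source may hold more compounds than are shown below. What is called first, only, known or untested is meant among the compounds shown, and "the series" means these compounds.

Compound 3 `CCN(CC)c1ccc(N2C(=O)NC3(CSC4=C3C(=O)c3ncccc3C4=O)C2=O)cc1` gives 30 nM in a functional assay on MCF7 cells (Homo sapiens) for antiproliferative activity, read by MTT assay, with a stated time of 96 h; a lower number here means a stronger inhibitor, a higher number a weaker inhibitor. Among the three compounds measured, compound 3 stands second highest: compound 1 `CN(C)c1ccc(N2C(=O)NC3(CSC4=C3C(=O)c3ncccc3C4=O)C2=O)cc1` gives 10 nM, and compound 2 `O=C1NC(=O)C2(CSC3=C2C(=O)c2ncccc2C3=O)N1`, which carries only a hydrogen where the others bear the aryl group, gives 120 nM. Among the compounds with values here, two steps bear on the question at hand. Removing the whole aryl group costs a great deal: a 12-fold higher number from compound 1 to compound 2 (1.08 log units; beyond the scatter). Enlarging the amino substituent costs less: a 3.0-fold higher number from compound 1 to compound 3 (0.48 log units; beyond the scatter).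

Compound 4 `CC(C)(C)c1ccc(N2C(=O)NC3(CSC4=C3C(=O)c3ncccc3C4=O)C2=O)cc1` has not yet been measured. Its change from compound 3 is tert-butyl in place of diethylamino on an aromatic carbon. The aryl ring itself is kept, so the large loss seen on its removal should not recur, while the two earlier changes at this aromatic carbon suggest that the substituent there does matter modestly. A modest weakening, or no change beyond the scatter, is therefore expected: a 1.7-fold higher number from compound 3 to compound 4 (0.22 log units; within the scatter). Compound 4 is estimated at 50 nM, with a range from 15 nM to 160 nM.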

Compound 4, half-maximal inhibitory concentration: 130 nM
For compound 4 the middle estimate is 2.6-fold (0.41 log units) below the measured one; low and high end bracket the measured number.
By their numbers in this assay, from the lowest: compound 1; then compound 3; then compounds 2 and 4 (each within the scatter of the next).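

In this assay the aryl group on the amide-type nitrogen brings no gain by itself: with tert-butyl on the aromatic carbon, compound 4 sits level with the hydrogen-bearing compound 2 (a 1.1-fold higher number from compound 2 to compound 4 (0.03 log units; within the scatter)). The substituent therefore decides whether the aryl group pays off, since replacing either amino group with tert-butyl gives a clear loss (a 4.3-fold higher number from compound 3 to compound 4 (0.64 log units; beyond the scatter); a 13-fold higher number from compound 1 to compound 4 (1.11 log units; beyond the scatter)), and this change removes the nitrogen and the one hydrogen-bond acceptor counted in the group that leaves. No measurement here accounts for this loss.

As far as these compounds go, whether the nitrogen itself matters remains open, as these compounds do not show where an unsubstituted phenyl, a methoxy group or a pyrrolidine ring would fall. A primary amine or a carboxylic acid at the same carbon is equally uncharted.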